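The compounds below may be only part of what the source reports. "The series", "measured", "known", "first", "only" and "open" are said of these compounds alone.

Measured so far: compound 1 `Cn1cnnc1SCC(=O)Nc1ccc(-c2nc(-c3ccccc3)c(-c3ccccc3)n2C)cc1` with 61.2% in a functional assay on MCF7 cells (Homo sapiens) for cytotoxicity, read by MTT assay, with a stated time of 24 h, tested at 16 ug/mL; on this read-out higher numbers stand for a stronger effect at the one concentration tested and lower numbers for a weaker effect; compound 2 `CN1CCN(CC(=O)Nc2ccc(-c3nc(-c4ccccc4)c(-c4ccccc4)n3C)cc2)CC1` with 30.1% in this assay.

Compound 2 stands lowest of the two numbers, its nearest neighbour being compound 1, a number a number 31.1 percentage points lower from compound 1 to compound 2 (beyond the scatter). Compound 3 `CCN1CCN(CC(=O)Nc2ccc(-c3nc(-c4ccccc4)c(-c4ccccc4)n3C)cc2)CC1` differs from compound 2 by methyl in place of hydrogen on a saturated chain carbon bound to an amine nitrogen in a ring. Within the data shown here, no measured step bears on this change; the only known step, a number 31.1 percentage points lower from compound 1 to compound 2 (beyond the scatter), concerns the whole ring group and not this single methyl. With nothing to guide it, the expected change a number 0.1 percentage points lower from compound 2 to compound 3 (within the scatter) is none beyond the scatter. Compound 3 is therefore estimated at 30%, ranging from 15% to 50%.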

Compound 3, a percentage reported as activity, at one concentration (the size of the read-out at that concentration, not a potency): 32.8%
Beside the measured number, compound 3's estimate is 2.8 percentage points below it; measured number inside the range.
By their numbers in this assay, from the lowest: compounds 2 and 3 (each within the scatter of the next); then compound 1.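

Lengthening the piperazine substituent from 4-methylpiperazin-1-yl to 4-ethylpiperazin-1-yl in this assay gives a number 2.7 percentage points higher from compound 2 to compound 3 (within the scatter) and so no resolved change at this position. The drop seen with the piperazine persists with the ethyl group, with a number 28.4 percentage points lower from compound 1 to compound 3 (beyond the scatter) for 4-ethylpiperazin-1-yl in place of (4-methyl-4H-1,2,4-triazol-3-yl)sulfanyl. No evidence bears on the cause of either step.

Open, as far as these compounds go, is whether a longer chain, a benzyl group or an acetyl group on that piperazine nitrogen would move the value. Also open, from the compounds shown here alone, is whether a morpholine in place of the piperazine would do so.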